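The source may hold more compounds than are shown below. What is called first, only, known or untested is meant among the compounds shown, and "the series" means these compounds.

Measured in a toxicity assay on cells (Macrophage, Mus musculus, strain BALB/c) for cytotoxicity, read by MTT assay; a higher number here means a weaker inhibitor, a lower number a stronger inhibitor:

- compound 1 `C=CCOc1cc(OC)c(C(=O)/C=C/Cc2ccccc2)c(OCC=C)c1`: 14800 nM
- compound 2 `C=CCOc1cc(OC)c(C(=O)/C=C/c2ccc(F)cc2)c(OCC=C)c1`: 13800 nM
- compound 3 `C=CCOc1cc(OC)c(C(=O)/C=C/c2ccccc2F)c(OCC=C)c1`: 13300 nM

Compound 3 stands level with the other two compounds, since its differences from both lie within the scatter of repeated measurements. The next compound, compound 4 `C=CCOc1cc(OC)c(C(=O)/C=C/c2ccc(OC)cc2)c(OCC=C)c1`, keeps the shared core but changes one group: 4-methoxyphenyl in place of 2-fluorophenyl on a double-bonded chain carbon bound to a double-bonded chain carbon. In words, 4-methoxyphenyl takes the place of 2-fluorophenyl on a double-bonded chain carbon bound to a double-bonded chain carbon.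

Three measured steps change this same place. Swapping benzyl for 4-fluorophenyl gives a 1.1-fold lower number from compound 1 to compound 2 (0.03 log units; within the scatter), and swapping it for 2-fluorophenyl gives a 1.1-fold lower number from compound 1 to compound 3 (0.05 log units; within the scatter). Swapping between the two fluorophenyl groups gives a 1.0-fold lower number from compound 2 to compound 3 (0.02 log units; within the scatter). All three are within the scatter, so this assay has so far shown little response to changes here. However, no measured compound carries a 4-methoxyphenyl group, so the range must stay fairly wide.

No change beyond the scatter is expected, and the estimated step is a 1.1-fold higher number from compound 3 to compound 4 (0.02 log units; within the scatter). Compound 4 is expected to give 14000 nM, with an estimated range of 7500 nM to 26000 nM.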

Compound 4, half-maximal inhibitory concentration: 18700 nM
Compound 4: middle estimate off by 1.3-fold (0.13 log units), on the low side, and the stated range covers the measured number.
By their numbers in this assay, from the lowest: compounds 3, 2, 1 and 4 (each within the scatter of the next).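

In this assay, 4-methoxyphenyl is a new kind of group at this place, yet all three steps to it stay within the scatter: a 1.4-fold higher number from compound 3 to compound 4 (0.15 log units; within the scatter), a 1.4-fold higher number from compound 2 to compound 4 (0.13 log units; within the scatter) and a 1.3-fold higher number from compound 1 to compound 4 (0.10 log units; within the scatter). The flat response already seen across benzyl and the two fluorophenyl groups therefore extends to a group that carries a hydrogen-bond acceptor, and swapping fluoro for methoxy on an aromatic carbon makes no readable difference either. No supporting measurement is available to explain this flat response.

As far as these compounds go, all four groups at this place are built around a benzene ring and have no net charge, so it remains open whether an amine or a carboxylic acid here would move the number beyond the scatter. A longer chain between the double-bonded chain carbon and the ring is also an open case.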